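The source may hold more compounds than are shown below. What is called first, only, known or untested is meant among the compounds shown, and "the series" means these compounds.

Measured compounds: compound 1 `Cc1nn(C)c2c(O)nc(-c3ccccc3)nc12` with 1020 nM in an assay on membranes from brain for binding affinity to adenosine receptor A1 (Rattus norvegicus), read by radioligand binding (on this read-out lower numbers stand for stronger inhibition and higher numbers for weaker inhibition), and compound 2 `Cc1ccc(-c2nc(O)c3c(n2)c(C)nn3C)cc1` with 400 nM in this assay. Of these two numbers, compound 1 has the higher one, and compound 2 lies a 2.6-fold lower number from compound 1 to compound 2 (0.41 log units; beyond the scatter) away, a step made by methyl in place of hydrogen on an aromatic carbon.

Compound 3 `COc1ccccc1-c1nc(O)c2c(n1)c(C)nn2C` differs from compound 1 by methoxy in place of hydrogen on an aromatic carbon, ortho to a large group. Going by the values given here, only the step from compound 1 to compound 2 bears on this change, and it was modest. A step of similar size toward a lower number is therefore expected, as a 1.5-fold lower number from compound 1 to compound 3 (0.16 log units; within the scatter), so compound 3 is estimated at 700 nM, within 250 nM to 2000 nM.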

Compound 3, half-maximal inhibitory concentration: 10000 nM
The estimate for compound 3 lay 14-fold (1.15 log units) below the measured number; measured number above the stated range.
By their numbers in this assay, from the lowest: compound 2; then compound 1; then compound 3.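

In this assay, methoxy on an aromatic carbon ortho to a large group moves the number the opposite way to the methyl change, with a 9.8-fold higher number from compound 1 to compound 3 (0.99 log units; beyond the scatter) against a 2.6-fold lower number from compound 1 to compound 2 (0.41 log units; beyond the scatter). A substituent on this ring therefore does not lower the number as such, though the two changes differ in both group and place, and these data cannot separate the two. Nothing available accounts for the rise.

From the compounds shown here alone, whether an amine or a chlorine atom on that same carbon would also raise the number stays open. So does the effect of methoxy on the carbon that carries methyl in compound 2.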